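Adding One Methyl to Compound 2

A few compounds are considered here, and "the series" means these few. Any claim that something is new, unique, unknown or untested is made for them only; others in the source may bear on it.

Compound 1 `O=S(=O)(c1ccccc1)c1nc2ccccc2nc1Nc1ccc(F)cc1` and compound 2 `O=S(=O)(c1ccccc1)c1nc2ccccc2nc1Nc1ccc(Cl)cc1` share one core and differ only by chloro in place of fluoro on an aromatic carbon. In a functional assay on PC-3 cells (Homo sapiens) for cytotoxicity, read by MTT assay, with a stated time of 72 h (a lower number here means a stronger inhibitor, a higher number a weaker inhibitor), compound 1 gives 14200 nM, and compound 2 gives 15300 nM; the step of a 1.1-fold higher number from compound 1 to compound 2 (0.03 log units; within the scatter) lies within the scatter, so the two numbers cannot be told apart. Compound 3 `Cc1ccc(S(=O)(=O)c2nc3ccccc3nc2Nc2ccc(Cl)cc2)cc1` carries methyl in place of hydrogen on an aromatic carbon. For the measured compounds named here, no measured step touches that ring; the single known step sits elsewhere and was flat. The expected step is therefore a 1.1-fold lower number from compound 2 to compound 3 (0.04 log units; within the scatter), none beyond the scatter. Compound 3 is estimated at 14000 nM, between 6000 nM and 35000 nM.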

Compound 3, half-maximal inhibitory concentration: 9660 nM
For compound 3 the middle estimate is 1.4-fold (0.16 log units) above the measured one; the range from low to high includes it.
By their numbers in this assay, from the lowest: compounds 3, 1 and 2 (each within the scatter of the next).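

For the compounds shown here, the phenyl to 4-methylphenyl change gives a 1.6-fold lower number from compound 2 to compound 3 (0.20 log units; within the scatter) in this assay and is the first reading at this ring. Adding one methyl here therefore leaves the number within the scatter, so this position, like the one changed from compound 1 to compound 2, has shown no step beyond it so far. No measurement bears on why the number sits where it does. From the compounds shown here alone, what an amine or a carboxylic acid would do at this position remains open. So does whether a longer chain here would give a step beyond the scatter.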